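Replacing the amide side chain of a cytotoxic stilbene-like series

The source may hold more compounds than are shown below. What is called first, only, known or untested is meant among the compounds shown, and "the series" means these compounds.

Measured compounds:
Compound 1, `CC1=C(C(C)C(=O)N(CCNC(C)C)C(C)C)c2cc(F)ccc2/C1=C\c1ccc([S+](C)[O-])cc1`, gives 21300 nM in a functional assay on MDA-MB-231 cells (Homo sapiens) for inhibition, read by CellTiter-Glo, with a stated time of 96 h; a higher number here means that more compound is tolerated, a lower number that less compound is tolerated.
Compound 2, `CC1=C(C(C)C(=O)NCCN2CCCCC2)c2cc(F)ccc2/C1=C\c1ccc([S+](C)[O-])cc1`, gives 39300 nM in this assay.

Compound 2 carries the larger of the two numbers, but the step of a 1.8-fold higher number from compound 1 to compound 2 (0.27 log units; within the scatter) lies within the usual scatter of repeated measurements, so the two compounds cannot really be told apart on these data.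

Compound 3, `CC1=C(C(C)C(=O)N2CCN(c3ccncc3)CC2)c2cc(F)ccc2/C1=C\c1ccc([S+](C)[O-])cc1`, differs from compound 2 at one place only: 4-(pyridin-4-yl)piperazin-1-yl in place of (2-(piperidin-1-yl)ethyl)amino on a carbonyl carbon. Within the data shown here, the single measured step that bears on this position, a 1.8-fold higher number from compound 1 to compound 2 (0.27 log units; within the scatter), exchanged one amine-bearing side chain on the same carbonyl carbon for another and produced no change beyond the scatter. Among the measured compounds shown here, nothing measured so far shows that this part of the molecule shifts the number in this assay, although a tertiary amide with an aromatic ring has not been tested, so the uncertainty is wide.

Compound 3 is therefore expected to give about 30000 nM in this assay, a change of a 1.3-fold lower number from compound 2 to compound 3 (0.12 log units; within the scatter), with a likely range from 9000 nM to 100000 nM.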

Compound 3, half-maximal cytotoxic concentration: 19600 nM
The estimate for compound 3 lay 1.5-fold (0.18 log units) above the measured number; low and high end bracket the measured number.
By their numbers in this assay, from the lowest: compounds 3, 1 and 2 (each within the scatter of the next).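

Compound 3 places a different kind of group on the carbonyl carbon: 4-(pyridin-4-yl)piperazin-1-yl, with a six-membered aromatic ring and no hydrogen-bond donor. Yet in this assay neither new step rises above the scatter (a 2.0-fold lower number from compound 2 to compound 3 (0.30 log units; within the scatter); a 1.1-fold lower number from compound 1 to compound 3 (0.04 log units; within the scatter)), although the first of these reaches the edge of it. The earlier step had compared only two amine-bearing chains, so the three compounds now show that this position can carry an aromatic ring-bearing group without a measurable shift in the number, and no measurement available here explains why.

All three groups shown contain more than one nitrogen, so it remains open whether a carboxylic acid or a plain alkyl chain with no nitrogen beyond the amide on this carbonyl carbon would give a number that stands clearly apart from these three. From the compounds shown here alone, it also remains open whether a primary amide, the smallest group at this position, would leave the number in this same range.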